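Swapping Chloro for Methyl on Two Different Cores

The source may report more compounds than this note shows. Statements on the series, on what has been measured and on what is new or still open speak of the compounds shown alone.

Of the compounds shown here, three have been measured in a functional assay on the whole organism (strain albino) for inhibition, with Rattus norvegicus as the target, read by paw edema, with stated times of 30 min and 1 h, at a dose of 50 mg/kg by the oral route; a higher number here means more inhibition at the dose given (going by the name of the read-out), a lower number less inhibition. Compound 1, `O=C(O)CCC(=O)/C=C/c1cn(-c2ccccc2)nc1-c1ccc(Cl)cc1`, gives 3.43% in this assay. Compound 2, `Cc1ccc(-c2nn(-c3ccccc3)cc2/C=C/C(=O)CCC(=O)O)cc1`, gives 4.41%. Compound 3, `CC(=O)Nc1ccc(OC(=O)c2cn(-c3ccccc3)nc2-c2ccc(Cl)cc2)cc1`, gives 17.8%, the highest of the three numbers, and its distance from compound 2 as well as from compound 1 lies beyond the usual scatter of this assay.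

Compound 2 differs from compound 1 in one place only: methyl in place of chloro on an aromatic carbon. The step that this change made in this assay is a number 1 percentage points higher from compound 1 to compound 2 (within the scatter), which falls within the scatter, so the two values cannot be ordered.

Compound 4, `CC(=O)Nc1ccc(OC(=O)c2cn(-c3ccccc3)nc2-c2ccc(C)cc2)cc1`, is not yet measured. It differs from compound 3 by methyl in place of chloro on an aromatic carbon. The groups that leave and enter and the place where they sit read the same, word for word, as in the change from compound 1 to compound 2, so it is the same change carried onto another core. The difference between the core of compound 3 and the core of compound 1 is not broken down here.

Within the data shown here, because the single earlier step of a number 1 percentage points higher from compound 1 to compound 2 (within the scatter) stayed within the scatter, the step expected on the new core is a number 1.2 percentage points higher from compound 3 to compound 4 (within the scatter), and this rests on that one example alone. The value expected for compound 4 in this assay is 19%, with an estimated range from 8% to 30%.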

Compound 4, a percentage reported as inhibition, in the whole organism at one dose (the size of the read-out at that dose, not a potency): 2.94%
Beside the measured number, compound 4's estimate is 16.1 percentage points above it; measured number outside the range, below it.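

In this assay methyl in place of chloro, the same change from 4-chlorophenyl to 4-methylphenyl, gave a number 14.9 percentage points lower from compound 3 to compound 4 (beyond the scatter) and so did not repeat on the core of compound 3 what it had done on the core of compound 1. This does not show which feature of the two cores sets the steps apart or why they part, and with a single pair on each core it gives no rule for predicting the step on any further core in this series. What it does show is that a step read on one of these cores cannot simply be carried onto the other, since the two steps do not agree: the same change on two cores in this assay, a number 1 percentage points higher (within the scatter) from compound 1 to compound 2 and a number 14.9 percentage points lower (beyond the scatter) from compound 3 to compound 4, 15.8 percentage points apart, beyond the scatter of two such steps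

The compounds shown leave open whether other groups in the place of the chloro, such as fluoro, methoxy or a longer chain, would give a step like the one on the core of compound 1 or the one on the core of compound 3. They also leave open whether the same change would keep the larger step if an amide replaced the ester link that compound 3 and compound 4 share.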